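Removing the hydroxy group from compound 2

A few compounds are considered here, and "the series" means these few. Any claim that something is new, unique, unknown or untested is made for them only; others in the source may bear on it.

- compound 1 `O=C(CSc1nnnn1-c1cccc2ccccc12)N/N=C/c1cccc(Cl)c1`: 240000 nM
- compound 2 `O=C(CSc1nnnn1-c1cccc2ccccc12)N/N=C/c1ccc(O)cc1`: > 309000 nM (a limit of the assay, not a number)

In an ADME assay on MT4 cells (Homo sapiens) for cytotoxicity, read by MTT assay (on this read-out higher numbers stand for lower toxicity in this test and lower numbers for higher toxicity in this test), compound 1 gives 240000 nM. Compound 2 stands at the limit of > 309000 nM in this assay, at which 1 of the 2 values shown sits, so it has a limit and no number.

The next compound, compound 3 `O=C(CSc1nnnn1-c1cccc2ccccc12)N/N=C/c1ccccc1`, carries hydrogen in place of hydroxy on an aromatic carbon, which turns 4-hydroxyphenyl into phenyl (hydrogen in place of hydroxy on an aromatic carbon). Among the compounds with values here, only one measured step bears on this change, and it also alters the same aryl group: an at least 1.2-fold higher number from compound 1 to compound 2 (0.10 log units; that floor lies within the scatter). Within the data shown here, no measured step yet isolates the hydroxy group itself, and the true value of compound 2 is unknown. Because of an at least 1.2-fold higher number from compound 1 to compound 2 (0.10 log units; that floor lies within the scatter) no step beyond the scatter is expected in this assay, although a small move towards lower numbers would not surprise, since the limit leaves room only on that side. The estimated step is an at least 1.2-fold lower number from compound 2 to compound 3 (0.09 log units; that floor lies within the scatter). Compound 3 is expected at 250000 nM, with an expected range of 120000 nM to 330000 nM.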

Compound 3, half-maximal cytotoxic concentration: 216000 nM
For compound 3 the middle estimate is 1.2-fold (0.06 log units) above the measured one; the range from low to high includes it.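

Taking away the hydroxy group gives an at least 1.4-fold lower number from compound 2 to compound 3 (0.15 log units; that floor lies within the scatter), so this change at the 4-hydroxyphenyl group can now be read on its own, though only as a floor and not as a full size. Hydrogen in place of chloro gives a 1.1-fold lower number from compound 1 to compound 3 (0.05 log units; within the scatter), which means that compound 1 and compound 3 do not separate in this assay, and the phenyl compound gives a real number for comparison with the other two aryl groups. Compound 2 carries a limit of the assay and not a number, so the true size of the hydroxy step stays unknown, and nothing shown places the hydroxy group beyond the scatter: the limit of > 309000 nM in this assay, at which 1 of the 3 values shown sits.

What the compounds shown leave open is whether any group on this aromatic ring moves the number beyond the scatter, for example an amine or a carboxylic acid in the place of hydroxy, para to a large group. On these data alone, it is also open whether a methoxy group at that place would stay with compound 3, and what a change in the shared core would do.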